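Aminophenyl positional change in a quinazoline-type series

A few compounds are considered here, and "the series" means these few. Any claim that something is new, unique, unknown or untested is made for them only; others in the source may bear on it.

Compound 1 `Fc1cccc(-c2nc(Nc3ccccc3Br)c3cc(F)ccc3n2)c1` and compound 2 `Nc1ccc(Nc2nc(-c3cccc(F)c3)nc3ccc(F)cc23)cc1` were tested in a functional assay on HT29-AK cells (Homo sapiens) for cytotoxicity, read by MTT assay, with a stated time of 48 h; on this read-out higher numbers stand for weaker inhibition and lower numbers for stronger inhibition. For compound 1 this assay reports only a limit, > 50000 nM. For compound 2 the same assay again reports only a limit, > 50000 nM. The step that the two limits leave unreadable from compound 1 to compound 2 therefore cannot be read in size or direction, and compound 2 stands at the limit alongside compound 1 (the limit of > 50000 nM in this assay, at which 2 of the 2 values shown sit).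

Compound 3 `Nc1cccc(Nc2nc(-c3cccc(F)c3)nc3ccc(F)cc23)c1` differs from compound 2 by 3-aminophenyl in place of 4-aminophenyl on a nitrogen on an aromatic ring. Among the measured compounds shown here, no measured step shows the effect of this kind of change; the only step in hand, from compound 1 to compound 2, is itself unreadable. With both measured compounds at the limit, compound 3 is expected to sit there as well, so the step that the limit leaves unreadable from compound 2 to compound 3 is estimated as none beyond the scatter. Compound 3 is therefore estimated at 60000 nM, in the range 20000 nM to 200000 nM, most likely reported as a limit.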

Compound 3, half-maximal inhibitory concentration: > 50000 nM
Compound 3 was reported as a limit (the forecaster's own chance of this, stated with the estimate: 85%); the middle value lies beyond the limit too.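

No step can be read among compound 1, compound 2 and compound 3, as each gives only a limit in this assay: the limit of > 50000 nM in this assay, at which 3 of the 3 values shown sit.

The compounds shown leave open whether 2-bromophenyl, 4-aminophenyl and 3-aminophenyl on the nitrogen differ at all in this assay.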